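The compounds below may be only part of what the source reports. "The series", "measured", "known", "first", "only" and "open" are said of these compounds alone.

Measured so far:
compound 1 `O=C(Nc1ccc([Se][Se]c2ccc(NC(=O)OCc3ccccc3)cc2)cc1)OCc1ccccc1` gives 69000 nM
compound 2 `CC(C)COC(=O)Nc1ccc([Se]C#N)cc1` gives 63700 nM
compound 3 `Cc1ccc(OC(=O)Nc2ccc([Se][Se]c3ccc(NC(=O)Oc4ccc(C)cc4)cc3)cc2)cc1` gives 70900 nM

All three numbers come from a functional assay on HT-29 cells (Homo sapiens) for cytotoxicity, read by MTT assay, with a stated time of 72 h; on this read-out lower numbers stand for higher toxicity in this test and higher numbers for lower toxicity in this test. Compound 2 shows the lowest of the three numbers, but its two neighbours sit very close to it: compound 1 is only slightly higher, and compound 3, the furthest, is also only slightly higher, and both of these gaps fall within the usual scatter of repeated measurements. So the three compounds cannot be told apart on this read-out; none of them is the most or the least toxic here.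

Compound 4 `N#C[Se]c1ccc(NC(=O)Oc2ccccc2)cc1` has not yet been tested. It differs from compound 2 in one place: phenyl in place of isobutyl on an oxygen next to a carbonyl group. Going by the values given here, no pair of measured compounds that differs in just one place is available, so there is no measured step to lean on. What the three numbers do show is that quite different groups on this carbamate oxygen, and even a quite different selenium part, all land in the same narrow band. On that basis the step from compound 2 to compound 4 is expected to be small, without a clear direction, and likely to stay within the scatter, which is what a 1.1-fold lower number from compound 2 to compound 4 (0.04 log units; within the scatter) expresses. Compound 4 is therefore estimated at 58000 nM, with a plausible range from 25000 nM to 130000 nM.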

Compound 4, concentration lethal to 50% of the cells: 71700 nM
For compound 4 the middle estimate is 1.2-fold (0.09 log units) below the measured one; the measured number falls inside the stated range.
By their numbers in this assay, from the lowest: compounds 2, 1, 3 and 4 (each within the scatter of the next).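

Going by these compounds alone, the pair of compound 2 and compound 4 is the first that differs in one place only, so it allows a direct reading of this position, on an oxygen next to a carbonyl group. In this assay, replacing isobutyl with phenyl gives a 1.1-fold higher number from compound 2 to compound 4 (0.05 log units; within the scatter), which means that exchanging an open chain for a six-membered aromatic ring of carbon only leaves the two compounds indistinguishable on this read-out. This is a single exchange, so it says nothing yet about other groups in this place, and no measurement is available that could explain the result.

From the compounds shown here alone, it remains open whether a longer chain, or a phenyl carrying an amine or a carboxylic acid, in this same place would move the number beyond the scatter. Within the data shown here, it is equally open whether the exchange of isobutyl for phenyl would read the same way with the different selenium part found in compound 1 and compound 3, since no pair with that selenium part differs in one place only.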